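Aryl variation on the anilide of the aminotriazole series

The source may report more compounds than this note shows. Statements on the series, on what has been measured and on what is new or still open speak of the compounds shown alone.

Compound 3 `COc1cc(-c2nnc(SCC(=O)Nc3ccccc3C)n2N)cc(OC)c1OC` carries (2-methylphenyl)amino on the carbonyl carbon. In a functional assay on PC-3 cells (Homo sapiens) for antiproliferative activity, read by MTT assay, with a stated time of 48 h (a lower number here means a stronger inhibitor, a higher number a weaker inhibitor), compound 3 gives > 100000 nM, which is a limit of the assay and not a number. The same limit holds for compound 1 `COc1cc(-c2nnc(SCC(=O)c3ccc(Br)cc3)n2N)cc(OC)c1OC`, which in this assay gives > 100000 nM. For the measured compounds named here, compound 2 `COc1cc(-c2nnc(SCC(=O)c3ccccc3F)n2N)cc(OC)c1OC` is the only member of the set with a number: in this assay compound 2 gives 43100 nM. Two steps are readable, namely an at least 2.3-fold lower number from compound 1 to compound 2 (0.36 log units; beyond the scatter) and an at least 2.3-fold higher number from compound 2 to compound 3 (0.36 log units; beyond the scatter); the step that the two limits leave unreadable from compound 1 to compound 3 cannot be sized, as the limit of > 100000 nM in this assay, at which 2 of the 3 values shown sit, shows. Compound 4 `COc1cccc(NC(=O)CSc2nnc(-c3cc(OC)c(OC)c(OC)c3)n2N)c1` differs from compound 3 by 3-methoxyphenyl in place of 2-methylphenyl on an amide-type nitrogen. Going by the values given here, no measured pair changes the aryl group that sits on the amide-type nitrogen, so none of the three steps bears directly on this change; the nearest comparison, the step of an at least 2.3-fold higher number from compound 2 to compound 3 (0.36 log units; beyond the scatter), concerns the amide-type nitrogen itself rather than the substituent on its phenyl. Among the compounds with values here, compound 3 stands at the limit, and no measured step points toward a lower number for an anilide, so the expected step of a number no higher from compound 3 to compound 4 (the limit leaves the size open) is none beyond the scatter. Compound 4 is expected to sit at or near the limit again. The estimate for compound 4 in this assay is 100000 nM, with a range from 30000 nM to 300000 nM.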

Compound 4, half-maximal inhibitory concentration: > 100000 nM
Compound 4: a limit, no number; the forecaster's own chance of this, stated with the estimate: 70%; the middle value lies on the limit itself.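

In this assay compound 4 gives > 100000 nM, which is a limit of the assay and not a number. For the compounds shown here, the amide-type nitrogen has now carried both 2-methylphenyl and 3-methoxyphenyl, and neither yields a number, so moving from a methyl-bearing to a methoxy-bearing phenyl at this place, with its added oxygen and hydrogen-bond acceptor, brings no readable gain; the only sized comparison remains the one against the ketone-linked compound, an at least 2.3-fold higher number from compound 2 to compound 4 (0.36 log units; beyond the scatter). The steps from compound 3 to compound 4 and from compound 1 to compound 4 cannot be read because both ends of each rest on the same limit: the limit of > 100000 nM in this assay, at which 3 of the 4 values shown sit.

Going by these compounds, the true values of the two anilides stay open, so any difference between 2-methylphenyl and 3-methoxyphenyl on the amide-type nitrogen remains unresolved, and compound 1 shows that the absence of this nitrogen does not by itself give a number. Also open, on these data alone, is whether a carboxylic acid or a dimethylamino group on that phenyl, or a longer chain in place of the phenyl, would bring an anilide into the measurable range of this assay.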